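A few compounds are considered here, and "the series" means these few. Any claim that something is new, unique, unknown or untested is made for them only; others in the source may bear on it.

Measured so far:
compound 1, `CCS(=O)(=O)Nc1cc(-c2ccc3ncnc(Nc4ccc(OC(F)(F)F)cc4)c3c2)cnc1OC`, 23700 nM;
compound 2, `CCS(=O)(=O)Nc1cc(-c2ccc3ncnc(Nc4ccc(OC)cc4)c3c2)cnc1OC`, 1790 nM.

In a functional assay on MCF7 cells (Homo sapiens) for cytotoxicity, read by sulforhodamine B assay, with a stated time of 72 h (on this read-out lower numbers stand for stronger inhibition and higher numbers for weaker inhibition), compound 2 gives the lower of the two numbers, and the step between the two is a 13-fold lower number from compound 1 to compound 2 (1.12 log units; beyond the scatter). Within the data shown here, that one step, which swaps a single group on an oxygen of the aniline ring, is the only guide to how this part of the molecule is tolerated, and it shows that the ring can move the number a long way.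

Compound 3, `CCS(=O)(=O)Nc1cc(-c2ccc3ncnc(Nc4cccc(C(=O)OC)c4)c3c2)cnc1OC`, is not yet measured. It differs from compound 2 by 3-(methoxycarbonyl)phenyl in place of 4-methoxyphenyl on a nitrogen on an aromatic ring. This is not the same kind of change as the measured step: the methoxy group is removed altogether and an ester is put on the ring at another position, so the step from compound 1 to compound 2 bears on it only in showing that this ring matters. Among the measured compounds shown here, no measured pair tells the direction. Compound 3 is therefore expected to lie close to compound 2, with a wide range, at an estimated 3000 nM (from 600 nM to 15000 nM), an expected step of a 1.7-fold higher number from compound 2 to compound 3 (0.22 log units; within the scatter).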

Compound 3, half-maximal inhibitory concentration: 10100 nM
The estimate for compound 3 lay 3.4-fold (0.53 log units) below the measured number, within the range that was stated.
By their numbers in this assay, from the lowest: compound 2; then compound 3; then compound 1.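

Swapping the 4-methoxyphenyl group on the nitrogen for 3-(methoxycarbonyl)phenyl in this assay gives a 5.6-fold higher number from compound 2 to compound 3 (0.75 log units; beyond the scatter), so the low number of compound 2 does not survive this change to the ring. The same ester-bearing ring still compares well with 4-(trifluoromethoxy)phenyl, giving a 2.3-fold lower number from compound 1 to compound 3 (0.37 log units; beyond the scatter), which places compound 3 between the other two compounds. The position therefore now gives three clearly separated results rather than one step between two closely related groups, with 4-methoxyphenyl giving the lowest number of the three, but nothing available explains this order.

Compound 3 differs from compound 2 both in the group it carries and in where that group sits on the ring, and no two compounds shown carry the same group at different places, so the contributions of these two differences cannot be separated. On these data alone, it also remains open how this position would respond to an aniline ring with no added group, or to one carrying an amine or a carboxylic acid.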